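Compound 3: swapping the group on the sulfonamide nitrogen

The source may report more compounds than this note shows. Statements on the series, on what has been measured and on what is new or still open speak of the compounds shown alone.

- compound 1 `CC(C)CN(c1cccc(F)c1)S(=O)(=O)c1ccc2c(c1)C(O)CC(C1CCOCC1)O2`: 3.39
- compound 2 `CC(C)CN(c1ccccc1C(F)(F)F)S(=O)(=O)c1ccc2c(c1)C(O)CC(C1CCOCC1)O2`: 4.14

In a physicochemical assay for lipophilicity, at pH 7.4 (on this read-out higher numbers stand for higher lipophilicity and lower numbers for lower lipophilicity), compound 2 stands highest of the two measured compounds, at 4.14. Compound 3 `Cc1ccc(N(CC(C)C)S(=O)(=O)c2ccc3c(c2)C(O)CC(C2CCOCC2)O3)c(C)c1` is still unmeasured and carries 2,4-dimethylphenyl in place of 2-(trifluoromethyl)phenyl on a sulfonamide nitrogen. Going by the values given here, only one measured step bears on this, a number 0.75 log units higher from compound 1 to compound 2 (beyond the scatter), a modest change at the same nitrogen that lies beyond the scatter. Among the compounds with values here, no measured compound yet carries 2,4-dimethylphenyl, so a smaller, slightly downward move within the scatter is expected. The estimated step is a number 0.14 log units lower from compound 2 to compound 3 (within the scatter) in this expectation. Compound 3 is estimated at 4, with an expected range from 3.6 to 4.4 for its measurement.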

Compound 3, distribution coefficient: 4.19
The estimate for compound 3 lay 0.19 log units below the measured number; measured number inside the range.
By their numbers in this assay, from the lowest: compound 1; then compounds 2 and 3 (each within the scatter of the next).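

On a sulfonamide nitrogen, 2,4-dimethylphenyl and 2-(trifluoromethyl)phenyl stand within the scatter of each other in this assay (a number 0.05 log units higher from compound 2 to compound 3 (within the scatter)). The step beyond the scatter away from 3-fluorophenyl also appears with a group that holds only carbon among its heavy atoms (a number 0.80 log units higher from compound 1 to compound 3 (beyond the scatter)), so at this position it does not depend on trifluoromethyl. Nothing available explains either step. The compounds shown leave open whether the 3-fluorophenyl number reflects its fluorine or where that fluorine sits, and how a phenyl ring bearing an amine or a carboxylic acid would read here.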